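Swapping thiophen-2-yl for 1H-pyrazol-3-yl in compound 2

The source may report more compounds than this note shows. Statements on the series, on what has been measured and on what is new or still open speak of the compounds shown alone.

For the measured compounds named here, in a functional assay for activation of Alpha-1B adrenergic receptor (Homo sapiens), read by calcium flux (a higher number here means a larger maximal response, a lower number a smaller maximal response), compound 2 `c1csc(-c2ccccc2OCC2=NCCN2)c1` gives 112%, the higher of the two numbers measured so far, while compound 1 `c1ccc(-c2cnccn2)c(OCC2=NCCN2)c1` gives 46%. Compound 3 `c1ccc(-c2cc[nH]n2)c(OCC2=NCCN2)c1` differs from compound 2 by 1H-pyrazol-3-yl in place of thiophen-2-yl on an aromatic carbon. Going by the values given here, the only measured step that bears on such an exchange of one aromatic ring for another, a number 66 percentage points higher from compound 1 to compound 2 (beyond the scatter), was large, so a large step is expected here as well, most likely downward. The step expected is a number 37 percentage points lower from compound 2 to compound 3 (beyond the scatter). Compound 3 is therefore estimated to give 75%, between 40% and 110%.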

Compound 3, largest response reached (reported as maximum), in percent of the reference or control that the assay uses: 39%
The estimate for compound 3 lay 36 percentage points above the measured number; measured number outside the range, below it.
By their numbers in this assay, from the lowest: compounds 3 and 1 (each within the scatter of the next); then compound 2.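

In this assay the ring on this aromatic carbon now shows a clear split. Replacing thiophen-2-yl with 1H-pyrazol-3-yl gives a number 73 percentage points lower from compound 2 to compound 3 (beyond the scatter) and replacing pyrazin-2-yl with 1H-pyrazol-3-yl gives a number 7 percentage points lower from compound 1 to compound 3 (within the scatter) so among these three compounds, only compound 2 stands apart, and the five-membered 1H-pyrazol-3-yl sits level with the six-membered pyrazin-2-yl. Nothing available here accounts for this split.

Where a plain phenyl or a furan-2-yl ring would fall at this place remains open. So does the effect of a methyl group on the pyrazole nitrogen.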